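This account rests on a few compounds, and the source may have more. Where it says the series, first, only, none or still open, it means among the compounds named here.

Measured compounds:
compound 1 `Cc1c(C(=O)c2cccc(CN(C)C)c2)oc2cc(-c3ccccc3)cc(O)c12`: 0.09 ug/mL
compound 2 `COc1ccc(CCOC(=O)c2oc3cc(-c4ccccc4)cc(O)c3c2C)cc1`: 0.02 ug/mL
compound 3 `Cc1c(C(=O)c2ccc(CN(C)C)cc2)oc2cc(-c3ccccc3)cc(O)c12`: > 4 ug/mL

All three were run in a functional assay on WI-38 VA13 cells (Homo sapiens) for cytotoxicity; a lower number here means that less compound is needed, a higher number that more compound is needed for the effect. Compound 1 gives a number, 0.09 ug/mL, and compound 2 likewise gives 0.02 ug/mL. For compound 3 the result is a limit only: > 4 ug/mL is an edge of this assay, and the limit of > 4 ug/mL in this assay, at which 1 of the 3 values shown sits, is where compound 3 sits. Compound 4 `CCc1ccc(C(=O)c2oc3cc(-c4ccccc4)cc(O)c3c2C)cc1` has not yet been measured in this assay. It differs from compound 3 by methyl in place of dimethylamino on a saturated chain carbon bound to an aromatic carbon. Among the measured compounds shown here, no measured pair shows this change, so its size is open; the step from compound 3 to compound 4 is expected to run toward a lower number, roughly an at least 8.0-fold lower number from compound 3 to compound 4 (0.90 log units; beyond the scatter), with wide uncertainty. Compound 4 is accordingly estimated at 0.5 ug/mL, in the range 0.05 ug/mL to 4 ug/mL.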

Compound 4, half-maximal effective concentration: > 4 ug/mL
Compound 4: only a limit was reported (the forecaster's own chance of this, stated with the estimate: 30%); middle value at least 8.0-fold (0.90 log units) from the limit.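

Compound 3 and compound 4 both stand as limits in this assay, and no step can be read between them: the limit of > 4 ug/mL in this assay, at which 2 of the 4 values shown sit.

The compounds shown leave open what methyl in place of dimethylamino does in this assay.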